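Pyridinyl for Dimethylaminophenyl: Expected Solubility of Compound 4

The compounds below may be only part of what the source reports. "The series", "measured", "known", "first", "only" and "open" are said of these compounds alone.

Measured compounds in a physicochemical assay for solubility, read by HPLC, using the shake flask method, measured as kinetic solubility, with a stated time of 2 h, at pH 7.4; a higher number here means a more soluble compound, a lower number a less soluble compound:
compound 1, `Cc1cc(NCc2ccco2)n2nc(C)c(-c3ccccc3)c2n1`, gives < 5000 nM, a limit of the assay.
compound 2, `Cc1cc(NCc2cccs2)n2nc(C)c(-c3ccccc3)c2n1`, gives < 5000 nM, a limit of the assay.
compound 3, `Cc1cc(NCc2ccccn2)n2ncc(-c3ccc(N(C)C)cc3)c2n1`, gives < 5000 nM, a limit of the assay.

Compound 3 stands at a limit rather than at a number; every value shown in this assay is such a limit, as the limit of < 5000 nM in this assay, at which 3 of the 3 values shown sit, records. Within the data shown here, the single step between measured compounds, a step that the two limits leave unreadable from compound 1 to compound 2, is not readable in size, since both of its values are limits.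

Compound 4, `Cc1cc(NCc2ccccn2)n2ncc(-c3ccncc3)c2n1`, differs from compound 3 in one place: pyridin-4-yl in place of 4-(dimethylamino)phenyl on an aromatic carbon. Among the measured compounds shown here, no measured step touches this change, and the one step available is unreadable, so there is no scale on which to place it. Compound 3 supplies only an upper bound, so compound 4 could sit at the same limit or somewhat above it; neither can be ruled out by the data. An estimate for compound 4 is therefore set near the limit, 5000 nM, in a range from 1000 nM to 25000 nM, which means an expected step of a number no lower from compound 3 to compound 4 (the limit leaves the size open). Its measured value will tell.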

Compound 4, solubility: 161000 nM
For compound 4 the middle estimate is 32-fold (1.51 log units) below the measured one; measured number outside the range, above it.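

Among these compounds, putting pyridin-4-yl in place of 4-(dimethylamino)phenyl on this aromatic carbon gives in this assay an at least 32-fold higher number from compound 3 to compound 4 (1.50 log units; beyond the scatter) and so shows that this position can carry a large change in the read-out, something the earlier compounds, all held at a limit, could not show. As far as these compounds go, compound 3 holds a limit and not a number, so the true size of this step stays open and only its least size is known. Compound 4 is the only compound shown with a number in this assay rather than a limit, which gives the series its first fixed point on the scale: the limit of < 5000 nM in this assay, at which 3 of the 4 values shown sit.

The compounds shown leave open whether the step follows from the ring nitrogen of pyridin-4-yl or from the loss of the dimethylamino group, and a pyridin-3-yl or a 4-(morpholin-4-yl)phenyl group on the same aromatic carbon would bear on that question. Also open, from the compounds shown here alone, is whether a change at this position would act in the same way in compound 1 and compound 2, whose step to each other cannot be read.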